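The source may report more compounds than this note shows. Statements on the series, on what has been measured and on what is new or still open speak of the compounds shown alone.

Three bromine-bearing lactones that share one core have been examined for their effect on prostate cancer cells in a functional assay on LNCaP cells (Homo sapiens) for cytotoxicity; on this read-out lower numbers stand for an effect already at smaller amounts and higher numbers for an effect only at larger amounts of compound. Compound 1, `CCC[C@@H](OC(C)=O)C1=C(Br)/C(=C/Br)OC1=O`, carries an acetyl on an oxygen on a saturated carbon; in this assay compound 1 gives 0.5 ug/mL. Compound 2, `CCC[C@@H](OC(C)=O)C1=C(Br)[C@@](CI)(OC)OC1=O`, gives 12.9 ug/mL in this assay, and compound 3, `CCCCC1=C(Br)C(OC)(C(Br)Br)OC1=O`, gives 6.6 ug/mL. Compound 1 therefore stands at the lowest number of the three, and its distance to both of the others lies beyond the scatter, with compound 3 the nearer of the two and compound 2 the further. Neither compound 2 nor compound 3 differs from compound 1 in a single place, so no one-step comparison is available among the measured compounds.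

Compound 4, `CCC[C@@H](O)C1=C(Br)/C(=C/Br)OC1=O`, is the next compound to be measured in this assay. It differs from compound 1 in one place only: hydrogen in place of acetyl on an oxygen on a saturated carbon Read one bond further out, the acetoxy of compound 1 becomes a hydroxy in compound 4, with the rest of the core untouched. Within the data shown here, no measured pair shows this exchange, so its effect must be guessed. The step of a 2.0-fold higher number from compound 1 to compound 4 (0.30 log units; within the scatter) is expected to be small, tending toward a somewhat higher number but perhaps not beyond the scatter. Compound 4 is thus expected to give about 1 ug/mL, within a range from 0.3 ug/mL to 3.5 ug/mL.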

Compound 4, concentration for half-maximal effect: 0.2 ug/mL
Compound 4: the middle estimate sits 5.0-fold (0.70 log units) above what was measured; measured number outside the range, below it.
By their numbers in this assay, from the lowest: compound 4; then compound 1; then compounds 3 and 2 (each within the scatter of the next).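

Among these compounds, with one place changed on the shared core, this assay now gives a first direct reading at this position: replacing acetyl with hydrogen on an oxygen on a saturated carbon gives a 2.5-fold lower number from compound 1 to compound 4 (0.40 log units; beyond the scatter) and this modest step lies beyond the scatter. The acetyl is therefore not required for the effect on these cells, and the free hydroxy in compound 4 gives 0.2 ug/mL with the rest of the structure untouched. Nothing available explains why the number moves in this direction.

The compounds shown leave open whether the effect at this position follows from the free hydroxy itself or would also persist with other groups, such as a methyl ether, a longer acyl chain like butyryl, or an amine in place of the oxygen. They also leave open whether acetoxy to hydroxy would produce a similar step on the core of compound 2, which carries the same acetoxy but has a methoxy and an iodomethyl group where compound 1 has its bromomethylidene group.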